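The compounds below may be only part of what the source reports. "The series", "measured", "known", "first", "only" and "open" are said of these compounds alone.

In an in vitro ADME assay on microsomes from liver (Homo sapiens) for metabolic stability, in the presence of a further agent that is not named here (on this read-out higher numbers stand for fast clearance and lower numbers for slow clearance), compound 1 `Cc1ccc(Cl)cc1Cn1c(C(=O)NCC(C)(C)CO)cc2cc(C#N)ccc21` gives 23 mL.min-1.g-1. Compound 2 `CC(C)(O)CCNC(=O)c1cc2cc(C#N)ccc2n1Cc1cccc(OC(F)(F)F)c1` gives < 6 mL.min-1.g-1, which is a limit of the assay and not a number. Compound 2 therefore stands at the limit of < 6 mL.min-1.g-1 in this assay, at which 1 of the 2 values shown sits. Compound 3 `N#Cc1ccc2c(c1)cc(C(=O)NCCC(O)C(F)(F)F)n2Cc1cccc(OC(F)(F)F)c1` differs from compound 2 in one place: 2,2,2-trifluoro-1-hydroxyethyl in place of 1-hydroxy-1-methylethyl on a saturated chain carbon, two bonds along the chain from an amide-type nitrogen. In words, 2,2,2-trifluoro-1-hydroxyethyl stands in place of 1-hydroxy-1-methylethyl on a saturated chain carbon, two bonds along the chain from an amide-type nitrogen. Among the measured compounds shown here, no measured pair of compounds shows the size of this change. The expectation starts from compound 2, whose < 6 mL.min-1.g-1 is a limit. The expected step is an at least 1.1-fold higher number from compound 2 to compound 3 (0.06 log units; that floor lies within the scatter), with no change beyond the scatter anticipated in either direction. For compound 3 the estimated clearance is 7 mL.min-1.g-1, with an expected range from 3 mL.min-1.g-1 to 18 mL.min-1.g-1.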

Compound 3, intrinsic clearance in microsomes: 31 mL.min-1.g-1
Beside the measured number, compound 3's estimate is 4.4-fold (0.65 log units) below it, outside the stated range (above it).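

In this assay, replacing 1-hydroxy-1-methylethyl with 2,2,2-trifluoro-1-hydroxyethyl gives an at least 5.1-fold higher number from compound 2 to compound 3 (0.71 log units; beyond the scatter), so the clearance read-out is sensitive to the group carried on this saturated chain carbon, two bonds along the chain from an amide-type nitrogen. The two groups have the same counts of hydrogen-bond donors and acceptors, and neither has a ring or a net charge, so those counts do not separate compound 2 from compound 3. The reading for compound 2 is a limit of the assay and not a number, so only the lower bound of the step is known: the limit of < 6 mL.min-1.g-1 in this assay, at which 1 of the 3 values shown sits.

The compounds shown leave open whether the step follows the three fluorine atoms or the loss of the methyl groups, which a difluoromethyl group at this place could help to separate. They also leave open how an amine or a carboxylic acid on this chain would read.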